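Five-membered aryl replacement on the shared core

The compounds below may be only part of what the source reports. "The series", "measured", "known", "first", "only" and "open" are said of these compounds alone.

Compound 1 `CCOc1nc(-c2nc3ccccc3n2C)cc(-c2ccc(Cl)cc2Cl)c1C#N` carries a 2,4-dichlorophenyl group, and in a functional assay on aorta (Rattus norvegicus, strain Wister) (on this read-out higher numbers stand for weaker inhibition and lower numbers for stronger inhibition), compound 1 gives 305000 nM. Compound 2 `CCOc1nc(-c2nc3ccccc3n2C)cc(-c2cccs2)c1C#N` carries a thiophen-2-yl group at that carbon instead; in this assay compound 2 gives 249000 nM. The step of a 1.2-fold lower number from compound 1 to compound 2 (0.09 log units; within the scatter) is within the scatter, so the two numbers cannot be told apart and compound 2 is not ranked against compound 1 on this basis. Compound 3 `CCOc1nc(-c2nc3ccccc3n2C)cc(-c2ccc(C)o2)c1C#N` differs from compound 2 by 5-methylfuran-2-yl in place of thiophen-2-yl on an aromatic carbon, the same aromatic carbon that was exchanged between compound 1 and compound 2. That step is the only measured one bearing on the new change, and it stayed within the scatter; an exchange of one five-membered aromatic ring with 1 hetero atom for another is therefore expected to give no step beyond the scatter in this assay. For compound 3 the expected value is 250000 nM, with a range from 100000 nM to 600000 nM, which corresponds to an expected 1.0-fold higher number from compound 2 to compound 3 (0.00 log units; within the scatter).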

Compound 3, half-maximal inhibitory concentration: 336000 nM
Compound 3: the middle estimate sits 1.3-fold (0.13 log units) below what was measured, and the stated range covers the measured number.
By their numbers in this assay, from the lowest: compounds 2, 1 and 3 (each within the scatter of the next).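

In this assay this carbon, ortho to the cyano group and opposite the ring nitrogen, now shows no readable response across three aromatic groups: the exchange of thiophen-2-yl for 5-methylfuran-2-yl gives a 1.3-fold higher number from compound 2 to compound 3 (0.13 log units; within the scatter), and the exchange of 2,4-dichlorophenyl for 5-methylfuran-2-yl gives a 1.1-fold higher number from compound 1 to compound 3 (0.04 log units; within the scatter), both direct comparisons. A change of hetero atom combined with an added methyl, and a change from a six-membered to a five-membered aromatic ring, therefore both stay within the scatter for these compounds. Nothing available offers a cause for this flat picture.

From the compounds shown here alone, it remains open whether a non-aromatic group at this carbon, such as an amine, a carboxylic acid or a longer alkyl chain, would move the number beyond the scatter. Replacing the ethoxy group or the nitrile elsewhere on the shared core is equally untested in the compounds shown here.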